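A few compounds are considered here, and "the series" means these few. Any claim that something is new, unique, unknown or untested is made for them only; others in the source may bear on it.

In an assay on T-REx-293 cells for inhibition of potassium channel subfamily T member 1 (Homo sapiens), read by patch clamp (on this read-out lower numbers stand for stronger inhibition and higher numbers for weaker inhibition), compound 1 `C[C@H](NC(=O)c1cc(C(F)(F)F)nn1C)c1nc(-c2ccccn2)no1` gives only a limit, > 30000 nM. For the measured compounds named here, compound 2 `C[C@H](NC(=O)c1cc(C(F)(F)F)nn1C)c1nc(-c2ccnc(N3CCCC3)c2)no1` gives 573 nM in this assay, the only number among the two values shown for it. The other value is the limit of > 30000 nM in this assay, at which 1 of the 2 values shown sits. Compound 3 `C[C@H](NC(=O)c1cc(C(F)(F)F)nn1C)c1nc(-c2ccnc(N(C)C)c2)no1` differs from compound 2 by dimethylamino in place of pyrrolidin-1-yl on an aromatic carbon. Going by the values given here, no measured pair of compounds shows a change of this kind, so no observed step guides the expectation. A modest weakening in this assay is expected, with the estimated step of a 2.1-fold higher number from compound 2 to compound 3 (0.32 log units; beyond the scatter). Compound 3 is therefore expected to give 1200 nM in this assay, within a range from 400 nM to 4000 nM.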

Compound 3, half-maximal inhibitory concentration: 454 nM
Beside the measured number, compound 3's estimate is 2.6-fold (0.42 log units) above it, and the stated range covers the measured number.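

In this assay, dimethylamino in place of pyrrolidin-1-yl gives a 1.3-fold lower number from compound 2 to compound 3 (0.10 log units; within the scatter), so at this place, next to the ring nitrogen, the five-membered non-aromatic ring can be replaced by a group with no ring without a change beyond the scatter. Exchanging pyridin-2-yl for 2-(dimethylamino)pyridin-4-yl gives an at least 66-fold lower number from compound 1 to compound 3 (1.82 log units; beyond the scatter), a large step whose size is only a bound. Compound 1 gives only a limit: the limit of > 30000 nM in this assay, at which 1 of the 3 values shown sits.

Still open, from the compounds shown here alone, is what plain pyridin-4-yl, without an amine, would give, so that step cannot be divided between the ring attachment and the dimethylamino group. Also open, going by these compounds, is whether a primary amino group, methylamino or morpholin-4-yl would hold the number at this place.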